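A few compounds are considered here, and "the series" means these few. Any claim that something is new, unique, unknown or untested is made for them only; others in the source may bear on it.

Working notes on a small set measured in a functional assay (muscle tissue) with Cavia porcellus as the target; a higher number here means that more compound is needed for the effect, a lower number that less compound is needed. Compound 1 `COC(=O)C1=C(C)N=C(C)/C(=C(\O)OC)C1c1c(F)c(F)c(F)c(F)c1F` gives 4.37 nM, compound 2 `COC(=O)C1=C(C)NC(C)=C(C(=O)OC)C1c1ccccc1` gives 28.2 nM, and compound 3 `COC(=O)C1=C(C)N=C(C)/C(=C(\O)OC)C1c1ccccc1I` gives 46.8 nM. On these numbers compound 3 has the highest value of the three. Its gap to compound 2 lies within the scatter, so those two cannot be ordered; its gap to compound 1 lies beyond the scatter, compound 1 needing less compound for the effect.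

The step under consideration leads from compound 3 to compound 4 `C=Cc1ccccc1C1C(C(=O)OC)=C(C)N=C(C)/C1=C(\O)OC`. The change is vinyl in place of iodo on an aromatic carbon. Neither group brings a hydrogen-bond donor or acceptor or a charge; the entering group brings one double bond outside aromatic rings.

Among the compounds with values here, no pair of measured compounds differs in a single place, so the three values offer no direct guide to what a vinyl in place of iodo does in this assay. The expectation is set close to compound 3, with no step beyond the scatter in either direction and a wide range. For compound 4 the estimated value in this assay is 40 nM, with a range from 13 nM to 130 nM. The estimated step of a 1.2-fold lower number from compound 3 to compound 4 (0.07 log units; within the scatter) is expected to lie within the scatter.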

Compound 4, half-maximal effective concentration: 4.47 nM
Estimate against measurement, compound 4: 8.9-fold (0.95 log units) above, outside the stated range (below it).
By their numbers in this assay, from the lowest: compounds 1 and 4 (each within the scatter of the next); then compounds 2 and 3 (each within the scatter of the next).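

Vinyl in place of iodo on an aromatic carbon, ortho to a large group, gives a 10-fold lower number from compound 3 to compound 4 (1.02 log units; beyond the scatter) in this assay, and this is the first single-place comparison available in the series. The group at this place can therefore move the number in this assay by much more than the scatter, even though the change from 2-iodophenyl to 2-vinylphenyl brings no hydrogen-bond donor or acceptor and no charge on either side, only one double bond outside aromatic rings. No measurement is available that bears on the reason for a step of this size, so it stands as an observation on this one pair.

Within the data shown here, the single pair leaves open whether the lower number belongs to vinyl specifically or would also appear with other groups at this place, such as ethyl, ethynyl, methoxy or an amine. From the compounds shown here alone, it is also open whether vinyl in place of iodo gives a step of similar size at other aromatic carbons of the ring or on a different core.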